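The compounds below may be only part of what the source reports. "The series", "measured", "known", "first", "only" and "open" are said of these compounds alone.

Compound 1 `COc1ccc(-c2ccc3c(NCCCNCc4cccc(OC)c4O)ccnc3c2)cc1` was run in an ADME assay for permeability, using PAMPA, with a stated time of 30 min, at pH 7.4 (a higher number here means that the compound crosses the layer faster, a lower number that the compound crosses the layer more slowly), where compound 1 gives 237 10^-6 cm/s. For the measured compounds named here, compound 2 `FC(F)(F)c1ccc(-c2ccc3c(NCCCNCc4ccco4)ccnc3c2)cc1` is the only other compound with a reading in this assay, and compound 2 gives 237 10^-6 cm/s. Going by the values given here, the two numbers are level at the digits reported, so compound 1 stands within the scatter of compound 2, and no step is drawn between them; the two share a core but differ in more than one place.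

Compound 3 `COc1cccc(Oc2ccc3c(NCCCNCc4cccc(OC)c4O)ccnc3c2)c1` has not been measured. It differs from compound 1 in a single place: 3-methoxyphenoxy in place of 4-methoxyphenyl on an aromatic carbon, in words a 3-methoxyphenoxy in place of a 4-methoxyphenyl on an aromatic carbon. Among the compounds with values here, no measured pair shows a change of this kind, and the two measured compounds, which differ from each other far more, give the same reading. For compound 3 the expected step is therefore a 1.1-fold lower number from compound 1 to compound 3 (0.03 log units; within the scatter) in this assay, a step not beyond the scatter, in no settled direction. Compound 3 is estimated at 220 10^-6 cm/s in this assay, with a range from 120 10^-6 cm/s to 400 10^-6 cm/s.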

Compound 3, apparent permeability: 317 10^-6 cm/s
For compound 3 the middle estimate is 1.4-fold (0.16 log units) below the measured one; the measured number falls inside the stated range.
By their numbers in this assay, from the lowest: compounds 1, 2 and 3 (each within the scatter of the next).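

In this assay, for the compounds shown here, the one-place swap of 4-methoxyphenyl for 3-methoxyphenoxy on this aromatic carbon gives a 1.3-fold higher number from compound 1 to compound 3 (0.13 log units; within the scatter), the first step that can be read at this position. The earlier pair could not show this, since compound 1 and compound 2 differ in more than one place and their level readings could not be tied to any single group. Here the reading can be tied to one place, and this change of group at that carbon does not move the number beyond the scatter, though no evidence is available to explain that outcome.

The compounds shown leave open whether a group of a different kind on this carbon, such as an amine, a carboxylic acid or a plain phenoxy without its methoxy, would give a step beyond the scatter. They also leave open whether the same swap would read alike with a longer chain in the shared core or with the different group that compound 2 carries at the far end of its chain.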